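Permeability notes: naphthyl for chlorofluorobenzyl on the shared core

The source may report more compounds than this note shows. Statements on the series, on what has been measured and on what is new or still open speak of the compounds shown alone.

Measured compounds:
compound 1, `COc1cccc(CNCCCNc2ccnc3cc(CCC(C)C)ccc23)c1O`: 23 10^-6 cm/s
compound 2, `COc1cccc(CNCCCNc2ccnc3cc(Cc4ccc(F)cc4Cl)ccc23)c1O`: 23 10^-6 cm/s

In an ADME assay for permeability, using PAMPA, with a stated time of 30 min, at pH 7.4 (on this read-out higher numbers stand for higher permeability and lower numbers for lower permeability), compound 1 gives 23 10^-6 cm/s, and compound 2 gives 23 10^-6 cm/s. The one measured step, no change at the digits printed from compound 1 to compound 2 (within the scatter), leaves the two compounds level at the digits shown, so compound 2 stands within the scatter of compound 1.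

Compound 3, `COc1cccc(CNCCCNc2ccnc3cc(-c4cccc5ccccc45)ccc23)c1O`, differs from compound 2 in one place: naphthalen-1-yl in place of 2-chloro-4-fluorobenzyl on an aromatic carbon. Within the data shown here, the only step that bears on this is the one just described, and it produced no change beyond the scatter; no other measured pair involves the group entering here. In this assay, then, no step beyond the scatter is expected, in either direction. Compound 3 is therefore estimated at 22 10^-6 cm/s, with a range from 11 10^-6 cm/s to 42 10^-6 cm/s. This estimate amounts to an expected step of a 1.0-fold lower number from compound 2 to compound 3 (0.02 log units; within the scatter).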

Compound 3, apparent permeability in the ADME assay: 237 10^-6 cm/s
Estimate against measurement, compound 3: 11-fold (1.03 log units) below, and the stated range ends below it.
By their numbers in the ADME assay, from the lowest: compounds 1 and 2 (each within the scatter of the next); then compound 3.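

In the ADME assay, this position does respond to the group it carries: compound 3, with naphthalen-1-yl, gives 237 10^-6 cm/s, which is (a 10-fold higher number from compound 2 to compound 3 (1.01 log units; beyond the scatter)) and (a 10-fold higher number from compound 1 to compound 3 (1.01 log units; beyond the scatter)), so the level reading of compound 1 (23 10^-6 cm/s) and compound 2 (23 10^-6 cm/s) does not hold for every group here. Among these compounds, in a physicochemical assay for acid dissociation, compound 2 gives 9.47 and compound 3 gives 9.47, and the same change gives (no change at the digits printed from compound 2 to compound 3 (within the scatter)), so the large step in the ADME assay comes with no step in the physicochemical assay. No measurement at hand accounts for the large step.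

As far as these compounds go, whether phenyl or naphthalen-2-yl on the same aromatic carbon would reach this level remains open. So does the effect of an amine or a carboxylic acid on the naphthalen-1-yl group.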